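The compounds below may be only part of what the source reports. "The series", "measured", "known", "first", "only" and "open" are said of these compounds alone.

The study sets two small series of acylated anilides side by side. Compound 1 `COC(=O)c1cc(NC(=O)C(C)Br)cc(C(=O)NC(N)=O)c1` and compound 2 `COC(=O)c1cc(NC(=O)CBr)cc(C(=O)NC(N)=O)c1` share one core, while compound 3 `Cc1c(NC(=O)C(C)Cl)cccc1C(=O)NC(N)=O` and the not yet measured compound 4 `Cc1c(NC(=O)CCl)cccc1C(=O)NC(N)=O` share another; the difference between the two cores is not broken down here. All of them belong to a functional assay on CCRF-CEM cells (Homo sapiens) for antiproliferative activity, read by trypan blue exclusion, with a stated time of 72 h; a higher number here means a weaker inhibitor, a lower number a stronger inhibitor.

In this assay compound 1 gives 2700 nM. In this assay compound 2 gives 1300 nM. The structural change between them is hydrogen in place of methyl on a saturated chain carbon bound to a bromine atom and a carbonyl carbon, and it produced a 2.1-fold lower number from compound 1 to compound 2 (0.32 log units; beyond the scatter).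

For compound 3 in this assay the result is only a limit of the assay, > 20000 nM. That is the point at which (the limit of > 20000 nM in this assay, at which 1 of the 3 values shown sits).

Compound 4 differs from compound 3 by hydrogen in place of methyl on a saturated chain carbon bound to a carbonyl carbon and a chlorine atom. Around the place the two cases are not identical: in compound 1 the saturated chain carbon is bound to a bromine atom and a carbonyl carbon, whereas in compound 3 it is bound to a carbonyl carbon and a chlorine atom, so the change is of the same kind as the one from compound 1 to compound 2, not the same.

A step of a number no higher from compound 3 to compound 4 (the limit leaves the size open) is expected, resting on the modest size of a 2.1-fold lower number from compound 1 to compound 2 (0.32 log units; beyond the scatter) and on the fact that compound 3 sits at a limit. Compound 4 is therefore estimated at 20000 nM in this assay, within a range from 7000 nM to 60000 nM, with a fair chance that the assay again reports only a limit.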

Compound 4, half-maximal inhibitory concentration: 2700 nM
Beside the measured number, compound 4's estimate is 7.4-fold (0.87 log units) above it, outside the stated range (below it).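

In this assay, hydrogen in place of methyl on the saturated chain carbon again lowered the number, with an at least 7.4-fold lower number from compound 3 to compound 4 (0.86 log units; beyond the scatter), so across these two pairs the direction of the change carried over from the core of compound 1 to the core of compound 3. The size of the change did not carry over, and the two steps cannot be treated as one shared increment: the same change on two cores in this assay, a 2.1-fold lower number (0.32 log units; beyond the scatter) from compound 1 to compound 2 and an at least 7.4-fold lower number (0.86 log units; beyond the scatter) from compound 3 to compound 4, at least 3.5-fold (0.55 log units) apart, beyond the scatter of two such steps
On these data alone, compound 3 sits at a limit of the assay, > 20000 nM, and the two pairs also differ in carrying bromine or chlorine on the chain carbon, so the true size of the second step remains unknown and the gap cannot be assigned to either the core or the halogen alone.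

The compounds shown leave open whether the two halogens would behave alike on a single core, with chlorine on the core of compound 1 or bromine on the core of compound 3. They also leave open how the number would move with a longer chain, such as an ethyl group in place of the methyl, or with a hydroxyl group in place of the halogen.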